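The source may report more compounds than this note shows. Statements on the series, on what has been measured and on what is new or still open speak of the compounds shown alone.

In a functional assay on RKO cells (Homo sapiens) for cytotoxicity, read by resazurin assay, with a stated time of 72 h (on this read-out lower numbers stand for stronger inhibition and higher numbers for weaker inhibition), compound 1 (`Cc1cn(-c2csc(Nc3ccc(Br)cc3)n2)c(C)n1`) gives 400 nM and compound 2 (`COc1ccc(Nc2nc(-n3ccnc3C)cs2)cc1`) gives 1600 nM, so compound 2 holds the higher of the two numbers, with a gap beyond the scatter. Compound 3 (`Cc1nccn1-c1csc(Nc2ccc(Br)cc2)n1`) has bromo in place of methoxy on an aromatic carbon. Within the data shown here, no measured step isolates this change. Compound 1 also carries bromo, and its 400 nM supports expecting a lower number in this assay, beyond the scatter. The expected change is a 3.2-fold lower number from compound 2 to compound 3 (0.51 log units; beyond the scatter). Compound 3 is estimated at 500 nM, with an expected range of 170 nM to 1500 nM.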

Compound 3, half-maximal inhibitory concentration: 30000 nM
The estimate for compound 3 lay 60-fold (1.78 log units) below the measured number; the measured number lies above the stated range.
By their numbers in this assay, from the lowest: compound 1; then compound 2; then compound 3.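

In this assay, bromo in place of methoxy on an aromatic carbon, para to a large group, gives a 19-fold higher number from compound 2 to compound 3 (1.27 log units; beyond the scatter) and so does not lower the number in this setting. Hydrogen in place of methyl on an aromatic carbon gives a 75-fold higher number from compound 1 to compound 3 (1.88 log units; beyond the scatter) and shows that bromo alone does not carry the low number of compound 1; among these compounds, that number appears only with bromo and the methyl together. No measurement here explains either step.

On these data alone, whether methoxy gains from the same methyl remains open. So does how chloro or an amine would read in place of bromo.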